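The source may report more compounds than this note shows. Statements on the series, on what has been measured and on what is new or still open speak of the compounds shown alone.

Working notes on the series. Compound 1 `Cc1ccc(C(=O)Nc2sc3c(c2C(N)=O)CCN(Cc2c(Cl)cccc2Cl)C3)cc1` carries a 2,6-dichlorophenyl on the saturated chain carbon bound to the ring amine nitrogen; in a functional assay on HeLa cells (Homo sapiens) for antiproliferative activity, with a stated time of 24 h (on this read-out lower numbers stand for stronger inhibition and higher numbers for weaker inhibition), compound 1 gives 47400 nM. Compound 2 `Cc1ccc(C(=O)Nc2sc3c(c2C(N)=O)CCN(Cc2ccc(Cl)cc2Cl)C3)cc1` returns only a limit of the assay, > 50000 nM. The step of an at least 1.0-fold higher number from compound 1 to compound 2 (0.02 log units; that floor lies within the scatter) therefore cannot be sized; both compounds are weak. Compound 3 `NC(=O)c1c(NC(=O)c2ccccc2F)sc2c1CCN(C(=O)Nc1ccccc1Cl)C2` changes the group on the ring amine nitrogen and the aryl on the carbonyl; compound 3 also returns only a limit, > 50000 nM. Compound 3 thus stands at the ceiling of the measured range, together with compound 2, as the limit of > 50000 nM in this assay, at which 2 of the 3 values shown sit, records.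

Compound 4 `Cc1ccc(C(=O)Nc2sc3c(c2C(N)=O)CCN(C(=O)Nc2ccccc2Cl)C3)cc1` is not yet measured. The change is 4-methylphenyl in place of 2-fluorophenyl on a carbonyl carbon. Among the compounds with values here, no measured step covers this exchange; the single measured step, an at least 1.0-fold higher number from compound 1 to compound 2 (0.02 log units; that floor lies within the scatter), concerns a different position and lies within the scatter. Compound 1 and compound 2 already carry the 4-methylphenyl on the carbonyl and are weak, and compound 3 carries the same urea as compound 4 and is weak. No step beyond the scatter is expected in this assay. Compound 4 is estimated at 60000 nM, with a range from 30000 nM to 150000 nM. The expected step that the limit leaves unreadable from compound 3 to compound 4 is thus essentially none, most likely another limit.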

Compound 4, half-maximal inhibitory concentration: 32900 nM
Compound 4: middle estimate off by 1.8-fold (0.26 log units), on the high side, and the stated range covers the measured number.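

Compound 4 puts a number on the (2-chlorophenyl)carbamoyl group on the amine nitrogen in a ring: in this assay compound 4 gives 32900 nM. Within the data shown here, compound 3, the only earlier compound with this group, returned only a limit. Exchanging 2,6-dichlorobenzyl for this group gives a 1.4-fold lower number from compound 1 to compound 4 (0.16 log units; within the scatter), so these two groups are not separated on this read-out. Putting 4-methylphenyl in place of 2-fluorophenyl on a carbonyl carbon gives an at least 1.5-fold lower number from compound 3 to compound 4 (0.18 log units; that floor lies within the scatter). Putting (2-chlorophenyl)carbamoyl in place of 2,4-dichlorobenzyl on an amine nitrogen in a ring gives an at least 1.5-fold lower number from compound 2 to compound 4 (0.18 log units; that floor lies within the scatter). Both of these steps start from a limit, and the series remains pressed against that ceiling: the limit of > 50000 nM in this assay, at which 2 of the 4 values shown sit.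

The compounds shown leave open whether any other group, such as a longer chain on the amine nitrogen in a ring or an amine or a carboxylic acid on the aryl at the carbonyl, would move the number beyond the scatter. As far as these compounds go, it also remains open how large a difference the limit conceals between compound 2 and compound 3.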